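Hydroxamate versus methoxy amide on two enantiomeric cores

This account rests on a few compounds, and the source may have more. Where it says the series, first, only, none or still open, it means among the compounds named here.

Measured in an assay on isolated protein for inhibition of Apoptosis regulator Bcl-2 (Homo sapiens), read by fluorescence polarization, with stated times of 5 min and 10 min; on this read-out lower numbers stand for stronger inhibition and higher numbers for weaker inhibition:
compound 1, `CC(C)=CCCC1=CC[C@H](C(=O)N(C)O)[C@@H](c2ccccc2)C1`: 2100 nM
compound 2, `CON(C)C(=O)[C@H]1CC=C(CCC=C(C)C)C[C@@H]1c1ccccc1`: 300 nM
compound 3, `CON(C)C(=O)[C@@H]1CC=C(CCC=C(C)C)C[C@H]1c1ccccc1`: > 23000 nM, a limit of the assay only

Compound 2 and compound 1 differ by hydrogen in place of methyl on an oxygen; this gives a 7.0-fold higher number from compound 2 to compound 1 (0.85 log units; beyond the scatter). Compound 2 and compound 3 differ by the two compounds have the same atoms and bonds and differ only in configuration as drawn: 2 of 2 stereo elements differ (all stereocentres are inverted: mirror images); a stereocentre at a saturated ring carbon is drawn S in compound 2 and R in compound 3; a stereocentre at a saturated ring carbon is drawn S in compound 2 and R in compound 3; the step is an at least 76-fold higher number from compound 2 to compound 3 (1.88 log units; beyond the scatter), and it rests on the fact that compounds 2 and 3 differ only in the configuration as drawn together with the limit of > 23000 nM in this assay, at which 1 of the 3 values shown sits.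

Compound 4, `CC(C)=CCCC1=CC[C@@H](C(=O)N(C)O)[C@H](c2ccccc2)C1`, is not yet measured. It differs from compound 3 by hydrogen in place of methyl on an oxygen, the same change as from compound 2 to compound 1, with the place described in identical words; the cores differ by the two compounds have the same atoms and bonds and differ only in configuration as drawn: 2 of 2 stereo elements differ (all stereocentres are inverted: mirror images); a stereocentre at a saturated ring carbon is drawn S in compound 2 and R in compound 3; a stereocentre at a saturated ring carbon is drawn S in compound 2 and R in compound 3. Among the measured compounds shown here, because a 7.0-fold higher number from compound 2 to compound 1 (0.85 log units; beyond the scatter) is the only measured instance of this change, a step of the same kind is expected for compound 4: a step that the limit leaves unreadable from compound 3 to compound 4. Compound 4 is expected near 120000 nM, between 23000 nM and 600000 nM, and most likely reported again only as a limit.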

Compound 4, inhibition constant: 2300 nM
Beside the measured number, compound 4's estimate is 52-fold (1.72 log units) above it; measured number outside the range, below it.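

In this assay, the change from methoxy to hydroxy does not carry from one core to its mirror image, the direction of the step reversing with an at least 10-fold lower number from compound 3 to compound 4 (1.00 log units; beyond the scatter): the same change on two cores in this assay, a 7.0-fold higher number (0.85 log units; beyond the scatter) from compound 2 to compound 1 and an at least 10-fold lower number (1.00 log units; beyond the scatter) from compound 3 to compound 4, at least 70-fold (1.84 log units) apart, beyond the scatter of two such steps. Within the hydroxy pair, inverting the core gives a 1.1-fold higher number from compound 1 to compound 4 (0.04 log units; within the scatter), whereas the methoxy pair gives an at least 76-fold higher number from compound 2 to compound 3 (1.88 log units; beyond the scatter), so the dependence on configuration appears only with methoxy: the fact that compounds 1 and 4 differ only in the configuration as drawn. Compound 3 gives > 23000 nM, a limit of the assay and not a number, so the size of its step stays unknown and no cause for the reversal is shown: the limit of > 23000 nM in this assay, at which 1 of the 4 values shown sits.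

Open, from the compounds shown here alone, is whether an ethoxy group or a longer alkoxy chain would behave like methoxy on both cores. Also open, going by these compounds, is where an amine or a carboxylic acid in place of the methoxy(methyl)carbamoyl group would fall.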